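The source may report more compounds than this note shows. Statements on the series, on what has been measured and on what is new or still open speak of the compounds shown alone.

In a functional assay on PC-3 cells (Homo sapiens) for cytotoxicity, read by WST assay, with a stated time of 72 h (a lower number here means a stronger inhibitor, a higher number a weaker inhibitor), compound 1 `CCCOc1ccc(C2(c3ccc(O)cc3)C(=O)Nc3c2ccc(F)c3F)cc1` gives > 1000 nM, which is a limit of the assay and not a number. Compound 2 `Cc1ccc2c(c1C)NC(=O)C2(c1ccc(O)cc1)C1CCCCCC1` gives > 1000 nM, which is likewise only a limit. Compound 3 `Cc1c(Cl)ccc2c1NC(=O)C2(c1ccc(O)cc1)C1CCCCCC1` differs from compound 2 in a single place: chloro in place of methyl on an aromatic carbon, with chloro in place of methyl on an aromatic carbon. Going by the values given here, no measured pair of compounds shows what a change like this does in this assay. The expected step of a number no higher from compound 2 to compound 3 (the limit leaves the size open) is therefore none beyond the scatter. Compound 3 is estimated at 1000 nM, within an expected range of 200 nM to 3000 nM.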

Compound 3, half-maximal inhibitory concentration: 150 nM
Estimate against measurement, compound 3: 6.7-fold (0.82 log units) above; the measured number lies below the stated range.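

In this assay, going by these compounds alone, the change from methyl to chloro on this aromatic carbon gives an at least 6.6-fold lower number from compound 2 to compound 3 (0.82 log units; beyond the scatter) and so brings the first reading that is a number, showing that this one position can move the result beyond the scatter. As far as these compounds go, compound 2 gives > 1000 nM as a limit of the assay and not a number, so the full size of the step stays open: the limit of > 1000 nM in this assay, at which 2 of the 3 values shown sit.

From the compounds shown here alone, only methyl and chloro appear at this position, so what fluoro, methoxy or an amine would do there remains open. Going by these compounds, whether chloro would have a similar effect on a core carrying other groups, such as that of compound 1, also remains open.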